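The compounds below may be only part of what the source reports. "The series", "measured", "known", "first", "only" and "open" are said of these compounds alone.

Of the compounds shown here, two have been measured so far in a functional assay on a cell-free system (plasma, Homo sapiens), with a stated time of 3 min; a higher number here means a weaker inhibitor, a lower number a stronger inhibitor. Compound 1, `CC(C)(C)C[C@@H](O)C(=O)N1[C@@H]2C[C@@H]2C[C@H]1C(=O)NCc1cc(Cl)ccc1-n1cnnn1`, gives 520 nM, and compound 2, `CC(C)(C)C[C@@H](O)C(=O)N1[C@H](C(=O)NCc2cc(Cl)ccc2-n2cnnn2)C[C@@H]2C[C@@H]21`, gives 570 nM. Compound 1 therefore stands level with compound 2, as the step is a 1.1-fold higher number from compound 1 to compound 2 (0.04 log units; within the scatter). What separates the pair is the fact that compounds 1 and 2 differ only in the configuration as drawn.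

The next compound, compound 3, `CCCC[C@@H](O)C(=O)N1[C@@H]2C[C@@H]2C[C@H]1C(=O)NCc1cc(Cl)ccc1-n1cnnn1`, changes the side chain of compound 1 instead: propyl in place of tert-butyl on a saturated chain carbon, two bonds along the chain from a carbonyl carbon and an oxygen on a saturated carbon. This puts propyl in place of tert-butyl on a saturated chain carbon, two bonds along the chain from a carbonyl carbon and an oxygen on a saturated carbon. Cut one bond further out, the same difference reads neopentyl to butyl.

The step from compound 1 to compound 2 leaves this side chain untouched, so it bears only weakly on the change and says nothing about its direction. A modest move towards a higher number in this assay is expected, held with little certainty.

The expected step is a 1.6-fold higher number from compound 1 to compound 3 (0.21 log units; within the scatter). For compound 3 the estimated value is 850 nM, with an expected range from 220 nM to 3300 nM.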

Compound 3, half-maximal inhibitory concentration: 870 nM
Beside the measured number, compound 3's estimate is 1.0-fold (0.01 log units) below it; the range from low to high includes it.
By their numbers in this assay, from the lowest: compounds 1, 2 and 3 (each within the scatter of the next).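

Among the compounds shown here, the earlier pair varied only the configuration as drawn, so compound 3 gives the first reading on the side chain. In this assay, putting propyl in place of tert-butyl on a saturated chain carbon, two bonds along the chain from a carbonyl carbon and an oxygen on a saturated carbon, gives a 1.7-fold higher number from compound 1 to compound 3 (0.22 log units; within the scatter), so on this single exchange the assay does not separate neopentyl from butyl at this place, and the tert-butyl group is not needed to stay level with compound 1. What is known about the two configurations has no bearing on this exchange, and nothing given here offers a reason for the result.

The compounds shown leave open whether a longer chain, a phenyl ring, an amine or a carboxylic acid at this place would stay level with compound 1 or move clearly away from it. They also leave open whether propyl in place of tert-butyl would read the same on the configuration of compound 2.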